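Aryl variation at the pyridine of the stilbene hydroxamate series

This account rests on a few compounds, and the source may have more. Where it says the series, first, only, none or still open, it means among the compounds named here.

Measured compounds:
compound 1 `O=C(NO)c1ccc(/C=C/c2ccnc(-c3cccc(O)c3)c2)cc1`, 19 nM
compound 2 `O=C(NO)c1ccc(/C=C/c2ccnc(-c3cccnc3)c2)cc1`, 14 nM

Both compounds share the hydroxamic acid stilbene core and differ only in the aromatic group on the core. In an assay on isolated protein for inhibition of protein deacetylase HDAC6 (Homo sapiens), read by fluorescence, with a stated time of 15 min (a higher number here means a weaker inhibitor, a lower number a stronger inhibitor), compound 1 gives 19 nM and compound 2 gives 14 nM. Among the compounds with values here, the one step measured, a 1.4-fold lower number from compound 1 to compound 2 (0.13 log units; within the scatter), falls within the scatter, so the two values cannot be ordered; compound 2 simply has the lower of the two numbers, with compound 1 close beside it.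

Compound 3 `COc1ccc(-c2cc(/C=C/c3ccc(C(=O)NO)cc3)ccn2)cc1` is not yet measured. The change from compound 2 is 4-methoxyphenyl in place of pyridin-3-yl on an aromatic carbon. Within the data shown here, the only step that bears on it is the exchange of one six-membered aromatic group for another at the same carbon, a 1.4-fold lower number from compound 1 to compound 2 (0.13 log units; within the scatter), which did not move the number beyond the scatter. On that basis a third six-membered aromatic group at this carbon is expected to give a similar number, with no step beyond the scatter in either direction: the estimated step is a 1.4-fold higher number from compound 2 to compound 3 (0.15 log units; within the scatter). For compound 3 the expected value in this assay is 20 nM, with a range from 8 nM to 50 nM.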

Compound 3, half-maximal inhibitory concentration: 110 nM
Compound 3: the middle estimate sits 5.5-fold (0.74 log units) below what was measured; the whole stated range lies below it.
By their numbers in this assay, from the lowest: compounds 2 and 1 (each within the scatter of the next); then compound 3.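

At the carbon next to the ring nitrogen, six-membered aromatic groups are not interchangeable in this assay: 4-methoxyphenyl gives a 7.9-fold higher number from compound 2 to compound 3 (0.90 log units; beyond the scatter) and a 5.8-fold higher number from compound 1 to compound 3 (0.76 log units; beyond the scatter). The loss of the ring nitrogen does not track this rise on its own, as compound 1 also carries a ring of carbon only, yet its value stands within the scatter of that of compound 2, and only compound 3 separates from the others. No measurement here explains the higher number of compound 3.

The compounds shown leave open whether the rise goes with the methoxy group itself, with its place on the ring, or with the larger group as a whole, and 3-methoxyphenyl, 4-hydroxyphenyl and unsubstituted phenyl at this carbon would bear directly on that. Also open, going by these compounds, is how 4-aminophenyl, 4-carboxyphenyl or a longer 4-alkoxyphenyl such as 4-ethoxyphenyl would read in this assay, and so whether the rise is specific to the methoxy group or extends to other groups in that ring place.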